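The source may hold more compounds than are shown below. What is called first, only, known or untested is meant among the compounds shown, and "the series" means these compounds.

Compound 1 `Cc1cc(NC(=O)Nc2ccccc2N)c2ccccc2n1` was examined in an ADME assay on BJ cells (Homo sapiens) for cytotoxicity, with a stated time of 72 h; on this read-out higher numbers stand for an effect only at larger amounts of compound and lower numbers for an effect already at smaller amounts. In this assay compound 1 gives > 25000 nM, which is a limit of the assay rather than a number. Compound 2 `Cc1cc(NC(=O)Nc2ccccc2C(C)(C)C)c2ccccc2n1` gives 22000 nM in this assay. Compound 3 `Cc1cc(NC(=O)Nc2ccccc2C(N)=O)c2ccccc2n1` gives > 25000 nM, again a limit of the assay. The steps of an at least 1.1-fold lower number from compound 1 to compound 2 (0.05 log units; that floor lies within the scatter) and an at least 1.1-fold higher number from compound 2 to compound 3 (0.05 log units; that floor lies within the scatter) stay within the scatter, and the step that the two limits leave unreadable from compound 1 to compound 3 cannot be read because of the limit of > 25000 nM in this assay, at which 2 of the 3 values shown sit. The unmeasured compound 4 `Cc1cc(NC(=O)Nc2cccc(Cl)c2)c2ccccc2n1` differs from compound 1 by 3-chlorophenyl in place of 2-aminophenyl on an amide-type nitrogen. Among the measured compounds shown here, none of the measured steps touches that group, so no movement beyond the scatter is expected. The expected step is a number no higher from compound 1 to compound 4 (the limit leaves the size open). Compound 4 is therefore estimated at 25000 nM, within a range from 10000 nM to 60000 nM.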

Compound 4, half-maximal effective concentration: > 25000 nM
Compound 4 gave a limit, no number; the forecaster's own chance of this, stated with the estimate: 60%; the middle value lies on the limit itself.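

No new step can be read between compound 1 and compound 4, since both give only a limit of the assay: the limit of > 25000 nM in this assay, at which 3 of the 4 values shown sit. The compounds shown leave open whether 3-chlorophenyl in place of 2-aminophenyl changes the read-out at all.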